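This account rests on a few compounds, and the source may have more. Where it says the series, first, only, none or still open, it means among the compounds named here.

Within the data shown here, in an ADME assay on HEp-2 cells (Homo sapiens) for cytotoxicity, read by MTT assay, with a stated time of 60 h (a lower number here means that less compound is tolerated, a higher number that more compound is tolerated), two compounds have numbers so far. Compound 1 `Cc1c(Br)cc2c(nc3n2[C@H]2OC[C@@H](OS(C)(=O)=O)[C@H]2OC3)c1Br` gives 15600 nM and compound 2 `COc1c(Br)cc2c(nc3n2[C@H]2OC[C@@H](O)[C@H]2OC3)c1Br` gives 259000 nM as the higher of the two, a gap beyond the scatter. Compound 3 `Cc1c(Br)cc2c(nc3n2[C@H]2OC[C@@H](O)[C@H]2OC3)c1Br` departs from compound 2 with a methyl in place of methoxy on an aromatic carbon, ortho to two bromo groups (methyl in place of methoxy on an aromatic carbon). Among the measured compounds shown here, no measured pair shows this change on its own, so the data give no direct size for it. The expectation therefore starts from compound 2 at 259000 nM and allows a small move toward a lower number in this assay only. The estimated 1.6-fold lower number from compound 2 to compound 3 (0.21 log units; within the scatter) would stay within the scatter. Compound 3 is estimated at 160000 nM as its half-maximal cytotoxic concentration, with an expected range (55000 nM to 400000 nM).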

Compound 3, half-maximal cytotoxic concentration: 34300 nM
Compound 3: middle estimate off by 4.7-fold (0.67 log units), on the high side; the whole stated range lies above it.
By their numbers in this assay, from the lowest: compound 1; then compound 3; then compound 2.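

In this assay, among these compounds, the aromatic carbon ortho to two bromo groups turns out to matter: methyl in place of methoxy gives a 7.6-fold lower number from compound 2 to compound 3 (0.88 log units; beyond the scatter) and is the first direct measure of this change, showing that less compound is tolerated with methyl there. Compound 3 also connects to compound 1 at the oxygen on a saturated carbon, where hydrogen in place of methylsulfonyl gives a 2.2-fold higher number from compound 1 to compound 3 (0.34 log units; beyond the scatter) as a second step beyond the scatter, so both places in the core of compound 3 register in this read-out. Nothing measured here explains either step.

On these data alone, how other groups at that aromatic carbon, such as an amine or a longer chain like ethoxy, would compare remains open. Whether the methyl-for-methoxy step keeps its size with methylsulfonyl on the oxygen also cannot be read from these compounds.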